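Compound 1 without its methyl: working notes

The source may hold more compounds than are shown below. What is called first, only, known or untested is meant among the compounds shown, and "the series" means these compounds.

Measured in a functional assay on MCF7 cells (Homo sapiens) for antiproliferative activity, read by MTT assay, with a stated time of 48 h; on this read-out higher numbers stand for weaker inhibition and lower numbers for stronger inhibition:
- compound 1 `COc1ccc(-c2nnc(NC(=O)/C=C/c3ccc(C)cc3)s2)cc1`: 0.31 ug/mL
- compound 2 `Cc1ccc(/C=C/C(=O)Nc2nnc(-c3ccc(C)cc3)s2)cc1`: 0.61 ug/mL
- compound 3 `Cc1ccc(/C=C/C(=O)Nc2nnc(-c3ccccc3)s2)cc1`: 1.23 ug/mL

Compound 1 sits at the low end of these numbers. The nearest step is a 2.0-fold higher number from compound 1 to compound 2 (0.29 log units; within the scatter), and the furthest is a 4.0-fold higher number from compound 1 to compound 3 (0.60 log units; beyond the scatter).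

The next compound is compound 4 `COc1ccc(-c2nnc(NC(=O)/C=C/c3ccccc3)s2)cc1`, related to compound 1 by hydrogen in place of methyl on an aromatic carbon. In words, this is hydrogen in place of methyl on an aromatic carbon, or 4-methylphenyl to phenyl. Going by the values given here, all three measured compounds carry this 4-methylphenyl group, so no measured step changes this place directly. Among the compounds with values here, the closest precedent is the same replacement made elsewhere in the molecule: a 2.0-fold higher number from compound 2 to compound 3 (0.30 log units; within the scatter). The step of a 4.0-fold higher number from compound 1 to compound 3 (0.60 log units; beyond the scatter) removes a different group and bears on this change only loosely.

A small move toward a higher number is therefore expected in this assay, about the size of the precedent. The expected step is a 1.9-fold higher number from compound 1 to compound 4 (0.29 log units; within the scatter). Compound 4 is estimated at 0.6 ug/mL, with an expected range from 0.25 ug/mL to 1.4 ug/mL.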

Compound 4, half-maximal inhibitory concentration: 0.78 ug/mL
Compound 4: middle estimate off by 1.3-fold (0.11 log units), on the low side; the range from low to high includes it.
By their numbers in this assay, from the lowest: compounds 1, 2, 4 and 3 (each within the scatter of the next, the first and the last beyond it).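

Going by these compounds alone, replacing the methyl of the 4-methylphenyl group with hydrogen gives the first direct reading at this position: in this assay, there is a 2.5-fold higher number from compound 1 to compound 4 (0.40 log units; beyond the scatter). Within the data shown here, this modest step shows that the methyl at this place contributes to the low number of compound 1, whereas the earlier compounds all carried it unchanged. The replacement now has two readings that agree in direction and size, so it looks transferable within this small set, and neither reading goes against it: the same change on two cores in this assay, a 2.0-fold higher number (0.30 log units; within the scatter) from compound 2 to compound 3 and a 2.5-fold higher number (0.40 log units; beyond the scatter) from compound 1 to compound 4, 1.2-fold (0.10 log units) apart, within the scatter of two such steps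

Open, on these data alone, is how an amine, a carboxylic acid or a longer chain at this place would read against methyl and hydrogen. Also open, as far as these compounds go, is whether the two methyl-to-hydrogen replacements would hold their size if made together in one compound.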